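The source may report more compounds than this note shows. Statements on the series, on what has been measured and on what is new or still open speak of the compounds shown alone.

Compound 1 `CC(Sc1nc2c(cnn2C)c(=O)n1-c1ccccc1)c1cccnc1` gives 95% in an assay on PEO1 cells for inhibition of Retinaldehyde dehydrogenase 3 (Homo sapiens), read by flow cytometry, with a stated time of 30 min, tested at 1 uM; on this read-out lower numbers stand for less inhibition and higher numbers for more inhibition at the one concentration tested (going by the name of the read-out).
Compound 2 `CC(Sc1nc2nn(C3COC3)cc2c(=O)n1-c1ccccc1)c1cccnc1` gives 99% in this assay.

Compound 1 stands lowest of the two numbers, but compound 2 lies only a little higher, within the scatter, so the two cannot be told apart. Compound 3 `C[C@H](Sc1nc2c(cnn2C)c(=O)n1-c1ccccc1)c1ccccc1` has not been measured in this assay. It differs from compound 1 in one place: 1-phenylethyl in place of 1-(pyridin-3-yl)ethyl on a sulfur. Among the measured compounds shown here, no measured pair shows what such a swap does, so the step from compound 1 to compound 3 in this assay is expected to be small, at most a slight drop, hardly beyond the scatter. Compound 3 is estimated at 90%, within 70% to 99%. That estimate means an expected step of a number 5 percentage points lower from compound 1 to compound 3 (within the scatter).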

Compound 3, a percentage reported as inhibition, at one concentration (the size of the read-out at that concentration, not a potency): 2%
Estimate against measurement, compound 3: 88 percentage points above, outside the stated range (below it).
By their numbers in this assay, from the lowest: compound 3; then compounds 1 and 2 (each within the scatter of the next).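

In this assay, the group on the sulfur proves decisive: 1-phenylethyl in place of 1-(pyridin-3-yl)ethyl gives a number 93 percentage points lower from compound 1 to compound 3 (beyond the scatter). The swap replaces the ring nitrogen with carbon, and compound 3 also carries a defined stereocentre, so these two differences cannot be separated here. No available evidence explains the loss. Still open, going by these compounds, is whether the ring nitrogen can sit elsewhere, as in 1-(pyridin-4-yl)ethyl, or be joined by a second one, as in 1-(pyrimidin-5-yl)ethyl. On these data alone, the mirror-image form of compound 3 also remains open.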